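The compounds below may be only part of what the source reports. "The series", "measured", "known", "first", "only" and "open" are said of these compounds alone.

Measured so far:
compound 1 `COc1ccccc1OC(=O)N(Nc1ccccc1)S(=O)(=O)c1ccc(C)cc1` gives 34.1 nM
compound 2 `COc1ccc(S(=O)(=O)N(Nc2ccccc2)C(=O)Oc2ccc3c(c2)CCC3)cc1` gives 4.5 nM
compound 3 `CCCc1ccc(S(=O)(=O)N(Nc2ccccc2)C(=O)Oc2ccc(Oc3ccccc3)cc2)cc1` gives 134 nM

These values come from a functional assay on RAW264.7 cells (Mus musculus), read by immunoassay, with a stated time of 24 h; a higher number here means a weaker inhibitor, a lower number a stronger inhibitor. Among the three, compound 3 has the highest number, so it is the weakest inhibitor of the set; its gap to compound 1 and its much larger gap to compound 2 both lie beyond the scatter. Compound 4 `Cc1cc(C)c(S(=O)(=O)N(Nc2ccccc2)C(=O)Oc2ccc(Oc3ccccc3)cc2)c(C)c1` has not yet been measured. It differs from compound 3 in one place: 2,4,6-trimethylphenyl in place of 4-propylphenyl on a sulfonyl sulfur. Among the compounds with values here, no pair of measured compounds differs in just one place, so no comparable step is known, and the three measured compounds vary in more than one part at once. Compound 4 is therefore expected to sit close to compound 3, with a step of a 1.1-fold lower number from compound 3 to compound 4 (0.05 log units; within the scatter) that may well fall within the scatter. The estimate for compound 4 is 120 nM, within 40 nM to 400 nM.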

Compound 4, half-maximal inhibitory concentration: 177 nM
Estimate against measurement, compound 4: 1.5-fold (0.17 log units) below; the measured number falls inside the stated range.
By their numbers in this assay, from the lowest: compound 2; then compound 1; then compounds 3 and 4 (each within the scatter of the next).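

In this assay, within the data shown here, replacing 4-propylphenyl with 2,4,6-trimethylphenyl on a sulfonyl sulfur gives a 1.3-fold higher number from compound 3 to compound 4 (0.12 log units; within the scatter) and provides the first comparison in this set where only one place differs. The two groups have the same atom count but a different arrangement, and here that rearrangement produces no change beyond the scatter. No measurement offered here explains this result. Still open, on these data alone, is whether a different group at this position, such as an amine or a carboxylic acid, would shift the number beyond the scatter. Whether this swap would behave the same way with other groups elsewhere on the shared core is also unknown.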